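The source may hold more compounds than are shown below. What is called first, only, known or untested is meant among the compounds shown, and "the series" means these compounds.

Measured in a functional assay on DLD-1 cells (Homo sapiens) for cytotoxicity, with a stated time of 48 h; a lower number here means a stronger inhibitor, a higher number a weaker inhibitor:

Compound 1 `CCOc1ccc2oc(/C=C/[S+](C)[O-])cc(=O)c2c1`: 4900 nM
Compound 2 `CCCCOc1ccc2oc(/C=C/[S+](C)[O-])cc(=O)c2c1`: 4800 nM
Compound 3 `CCC(=O)Oc1ccc2oc(/C=C/[S+](C)[O-])cc(=O)c2c1`: 9000 nM

Among these three numbers compound 1 stands second highest. Its nearest neighbour is compound 2, with a 1.0-fold lower number from compound 1 to compound 2 (0.01 log units; within the scatter), and its furthest is compound 3, with a 1.8-fold higher number from compound 1 to compound 3 (0.26 log units; within the scatter), so all three compounds sit within the usual scatter of one another.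

The unmeasured compound is compound 4 `CC(C)Oc1ccc2oc(/C=C/[S+](C)[O-])cc(=O)c2c1`. It differs from compound 1 by methyl in place of hydrogen on a saturated chain carbon bound to an oxygen on an aromatic ring and a saturated chain carbon. Among the measured compounds shown here, the step that bears most directly on this change is the one from compound 1 to compound 2, where a chain carbon likewise gained carbon and the number barely moved: a 1.0-fold lower number from compound 1 to compound 2 (0.01 log units; within the scatter). The other two steps, a 1.8-fold higher number from compound 1 to compound 3 (0.26 log units; within the scatter) and a 1.9-fold higher number from compound 2 to compound 3 (0.27 log units; within the scatter), exchange the alkyl chain for a propanoyl group and also stay within the scatter. Nothing measured here suggests that adding a methyl to the chain shifts the number, so the expected step is one of no change beyond the scatter: a 1.0-fold higher number from compound 1 to compound 4 (0.01 log units; within the scatter). The estimate for compound 4 is therefore 5000 nM, with a range of 2500 nM to 10000 nM.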

Compound 4, half-maximal inhibitory concentration: 8000 nM
Estimate against measurement, compound 4: 1.6-fold (0.20 log units) below; measured number inside the range.
By their numbers in this assay, from the lowest: compounds 2, 1, 4 and 3 (each within the scatter of the next).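

Replacing ethoxy with isopropoxy gives the first branched chain at this oxygen in this assay, and the change stays small (a 1.6-fold higher number from compound 1 to compound 4 (0.21 log units; within the scatter)). Compared with the straight butyl chain (a 1.7-fold higher number from compound 2 to compound 4 (0.22 log units; within the scatter)) and the propanoyl group (a 1.1-fold lower number from compound 3 to compound 4 (0.05 log units; within the scatter)), the isopropyl group also shows no difference beyond the scatter, so branching at the carbon bound to the oxygen does not separate compound 4 from the other three. No supporting data are available to explain this result.

All four groups on this oxygen are small and carbon-based, so these compounds leave open whether a larger or chemically different group would move the number beyond the scatter. A chain ending in an amine or a carboxylic acid, or a benzyl group, would test this.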